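Long-chain esters in the growth assay: compound 3

This account rests on a few compounds, and the source may have more. Where it says the series, first, only, none or still open, it means among the compounds named here.

Measured in a functional assay on COLO 205 cells (Homo sapiens) for antiproliferative activity; a higher number here means a weaker inhibitor of growth, a lower number a stronger inhibitor of growth:
- compound 1 `CCCCCOCCCCCCC/C=C1\CC(CO)(COC(=O)C(C)(C)C)OC1=O`: 0.491 ug/mL
- compound 2 `CC(C)(C)C(=O)OCC1(CO)C/C(=C\CCCCCCCCCCCCCCC=O)C(=O)O1`: > 10 ug/mL (a limit)

Compound 2 has no number in this assay, only the limit > 10 ug/mL. The same picture in the series: the limit of > 10 ug/mL in this assay, at which 1 of the 2 values shown sits.

Compound 3 `CC(=O)OCCCCCCCCCCCCCCC/C=C1\CC(CO)(COC(=O)C(C)(C)C)OC1=O` differs from compound 2 by acetoxymethyl in place of formyl on a saturated chain carbon, ten or more bonds along the chain from a double-bonded chain carbon. This places acetoxymethyl in place of formyl on a saturated chain carbon, ten or more bonds along the chain from a double-bonded chain carbon.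

Among the measured compounds shown here, one measured step bears on this change: an at least 20-fold higher number from compound 1 to compound 2 (1.30 log units; beyond the scatter). It is large and beyond the scatter, and it brought in the formyl group that now leaves, together with a different chain. It therefore does not isolate the effect of formyl, and its size is known only as a bound. Compound 3, like compound 1, carries no formyl, so a partial return towards compound 1 is expected, not a full one.

The expected move is an at least 3.3-fold lower number from compound 2 to compound 3 (0.52 log units; beyond the scatter), towards stronger growth inhibition, although another reading at the limit remains possible. Compound 3 is estimated at 3 ug/mL, with an expected range of 0.6 ug/mL to 10 ug/mL.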

Compound 3, concentration for 50% growth inhibition: 2.1 ug/mL
The estimate for compound 3 lay 1.4-fold (0.15 log units) above the measured number; the range from low to high includes it.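

In this assay, a long chain ending in acetoxymethyl gives a measurable level of growth inhibition, which the formyl end of compound 2 did not: an at least 4.7-fold lower number from compound 2 to compound 3 (0.67 log units; beyond the scatter). Compound 2 has only a limit, so the size of that step is a bound and the true gap may be larger: the limit of > 10 ug/mL in this assay, at which 1 of the 3 values shown sits. Growth inhibition at this end of the chain therefore does not require the pentyloxy group of compound 1, but the recovery is only partial: a 4.3-fold higher number from compound 1 to compound 3 (0.63 log units; beyond the scatter), which leaves the 8-acetoxyoctyl chain weaker than the pentyloxy chain by more than the scatter.

As far as these compounds go, the change from formyl to acetoxymethyl removes one group and adds another, so it remains open whether the gain comes from the ester itself or simply from the loss of the formyl group; a hydroxyl or a carboxylic acid at the same chain end would help separate the two. Also open, from the compounds shown here alone, is whether a shorter chain with the acetoxy end, or an amine at that end, would close the remaining gap to compound 1.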